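The compounds below may be only part of what the source reports. "The series", "measured", "known", "first", "only" and "open" are said of these compounds alone.

Three members of this series have been run in an in vitro functional assay on cells for agonist activity at Bombesin receptor subtype-3 (Homo sapiens), read by luminescence and calcium flux; a lower number here means that less compound is needed, a higher number that more compound is needed for the effect. Compound 1 `CCCCc1cnc(C(CCCO)Cc2ccc(-c3ccccc3C(=O)O)cc2)[nH]1` gives 1900 nM in this assay, compound 2 `CCCCc1cnc(C(CCCC)Cc2ccc(-c3ccccc3C(=O)O)cc2)[nH]1` gives 2660 nM, and compound 3 `O=C(O)c1ccccc1-c1ccc(CCc2ncc(CC3CCC3)[nH]2)cc1` gives 588 nM. Going by the values given here, the only single-point step among the three, a 1.4-fold higher number from compound 1 to compound 2 (0.15 log units; within the scatter), is methyl in place of hydroxy on a saturated chain carbon, four bonds along the chain from an aromatic carbon, and it stays within the scatter. Compound 3 holds the lowest of the three numbers; its gap to compound 1 and its gap to compound 2 are both beyond the scatter, so compound 3 is the most potent member so far.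

Compound 4 `N#Cc1ccccc1Cc1cnc(CCc2ccc(-c3ccccc3C(=O)O)cc2)[nH]1` differs from compound 3 in one place: 2-cyanophenyl in place of cyclobutyl on a saturated chain carbon bound to an aromatic carbon. Among the compounds with values here, no measured step covers a change of this kind; the step from compound 1 to compound 2 alters a chain end elsewhere in the molecule and says nothing about swapping a small saturated ring for an aromatic one carrying a nitrile. Within the data shown here, with no precedent, the working expectation is a number close to that of compound 3, but with a wide band in either direction. Compound 4 is therefore expected at about 800 nM, between 200 nM and 3200 nM. That amounts to an expected step of a 1.4-fold higher number from compound 3 to compound 4 (0.13 log units; within the scatter). The measurement is pending.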

Compound 4, half-maximal effective concentration: 5480 nM
Estimate against measurement, compound 4: 6.9-fold (0.84 log units) below, and the stated range ends below it.
By their numbers in this assay, from the lowest: compound 3; then compounds 1 and 2 (each within the scatter of the next); then compound 4.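

At the saturated chain carbon bound to an aromatic carbon, the group carried clearly matters: in this assay, 2-cyanophenyl in place of cyclobutyl gives a 9.3-fold higher number from compound 3 to compound 4 (0.97 log units; beyond the scatter). This single-point step lies beyond the scatter, unlike the only earlier one, which was made at a chain end elsewhere in the molecule. The change is composite, going from 4 heavy atoms to 8 and from a four-membered non-aromatic ring to a six-membered aromatic ring, with a nitrile entering at the same time, so the step cannot be assigned to any one of these features, and no supporting data bear on why the number rises.

On these data alone, it remains open whether the rise goes with the aromatic ring or with the nitrile; unsubstituted phenyl at this place would separate the two, while cyclopentyl or cyclohexyl would test a larger saturated ring. As far as these compounds go, it is also open whether the same step would appear on the core of compound 1 or compound 2, which carries a further chain on the carbon bound to the aromatic ring.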